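From Methyl to Ethyl on the Shared Core

The source may hold more compounds than are shown below. What is called first, only, known or untested is meant among the compounds shown, and "the series" means these compounds.

Compound 2 `Cc1cc(-c2sc(Cc3cccc(C(F)(F)F)c3)nc2C)ccc1C(N)=O` gives 86% in a functional assay on cells for agonist activity at G-protein coupled receptor 52 (Homo sapiens), read by AlphaScreen and cAMP accumulation, with a stated time of 30 min (on this read-out lower numbers stand for smaller maximal responses and higher numbers for larger maximal responses), and compound 1 `Cc1nc(Cc2cccc(C(F)(F)F)c2)sc1-c1ccc(C(N)=O)cc1` gives 93%; the step of a number 7 percentage points lower from compound 1 to compound 2 (within the scatter) separates them, so the two numbers stand together within the scatter. Compound 3 `CCc1cc(-c2sc(Cc3cccc(C(F)(F)F)c3)nc2C)ccc1C(N)=O` differs from compound 2 by methyl in place of hydrogen on a saturated chain carbon bound to an aromatic carbon. Among the compounds with values here, the only measured step that bears on this change is a number 7 percentage points lower from compound 1 to compound 2 (within the scatter), which added a methyl without moving the read-out beyond the scatter. Compound 3 is therefore expected to show a number 1 percentage points lower from compound 2 to compound 3 (within the scatter), no step beyond the scatter. The estimate for compound 3 is 85%, within 72% to 98%.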

Compound 3, largest response reached (Emax), in percent of the reference or control that the assay uses: 84%
Compound 3: middle estimate off by 1 percentage points, on the high side; measured number inside the range.
By their numbers in this assay, from the lowest: compounds 3, 2 and 1 (each within the scatter of the next).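

Going from methyl to ethyl on this saturated chain carbon gives a number 2 percentage points lower from compound 2 to compound 3 (within the scatter) in this assay, so this position takes the ethyl group with no step beyond the scatter. Measured against hydrogen on the aromatic carbon, the ethyl group gives a number 9 percentage points lower from compound 1 to compound 3 (within the scatter) and so also stays within the scatter of the compound without a substituent there. Nothing available here accounts for this result. On these data alone, whether a longer chain, an amine or a carboxylic acid at this position would keep the maximal response within the same scatter stays open.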